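A few compounds are considered here, and "the series" means these few. Any claim that something is new, unique, unknown or untested is made for them only; others in the source may bear on it.

Measured so far:

Compound 1 `CNc1nc2c(N)ncnc2n1[C@@H]1O[C@H](CN(C)CCCCON)[C@@H](O)[C@H]1O`: 49 nM
Compound 2 `CN(CCC(N)=O)C[C@H]1O[C@@H](n2cnc3c(N)ncnc32)[C@H](O)[C@@H]1O`: 7000 nM

In an assay on isolated protein for inhibition of S-adenosylmethionine decarboxylase proenzyme (Homo sapiens) (a higher number here means a weaker inhibitor, a lower number a stronger inhibitor), compound 2 gives the higher of the two numbers, and its gap to compound 1 lies well beyond the usual scatter. Compound 3 `CCc1nc2c(N)ncnc2n1[C@@H]1O[C@H](CN(C)CCC(N)=O)[C@@H](O)[C@H]1O` is compound 2 with ethyl in place of hydrogen on an aromatic carbon. Among the measured compounds shown here, no measured pair shows this change on its own, so its effect can only be guessed. The expectation is a step toward a lower number, clearly larger than the scatter. Compound 3 is estimated at 600 nM, with a plausible range from 100 nM to 3500 nM. This corresponds to an expected step of a 12-fold lower number from compound 2 to compound 3 (1.07 log units; beyond the scatter).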

Compound 3, half-maximal inhibitory concentration: 4000 nM
For compound 3 the middle estimate is 6.7-fold (0.82 log units) below the measured one; the measured number lies above the stated range.
By their numbers in this assay, from the lowest: compound 1; then compounds 3 and 2 (each within the scatter of the next).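

In this assay, ethyl in place of hydrogen gives a 1.8-fold lower number from compound 2 to compound 3 (0.24 log units; within the scatter) on this aromatic carbon between two ring nitrogen atoms. With the side chain of compound 2, this position therefore takes an ethyl group, with its two added carbons, without a change that stands out from repeat-measurement noise. No measurement shown here offers an explanation for this result. Going by these compounds, whether an amine or a longer chain such as propyl on the same carbon would shift the number remains open. So does whether ethyl would have the same small effect with a different side chain.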